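The source may report more compounds than this note shows. Statements on the series, on what has been measured and on what is new or still open speak of the compounds shown alone.

In a functional assay on CCRF-CEM cells (Homo sapiens) for cytotoxicity, in the presence of a further agent that is not named here (a lower number here means a stronger inhibitor, a higher number a weaker inhibitor), compound 1 `Nc1nc(N)c(CCCNc2cc(F)ccc2[N+](=O)[O-])c(O)n1` reads > 100000 nM as a limit of the assay and not a number. In this assay, going by the values given here, compound 2 `CC(C)(C)OC(=O)CCC(Nc1ccc(CN(CCCc2c(N)nc(N)nc2O)c2cc(F)cc(F)c2[N+](=O)[O-])cc1)C(=O)OC(C)(C)C` gives 7700 nM as the only actual number so far. Compound 3 `CC(C)(C)OC(=O)CCC(Nc1ccc(CN(CCCc2c(N)nc(N)nc2O)c2ccc([N+](=O)[O-])c(F)c2F)cc1)C(=O)OC(C)(C)C` is compound 2 with one swap, 2,3-difluoro-4-nitrophenyl in place of 3,5-difluoro-2-nitrophenyl on an amine nitrogen with the same atoms joined differently. Among the compounds with values here, no measured pair shows what such a swap does. The estimated step of a 1.1-fold lower number from compound 2 to compound 3 (0.04 log units; within the scatter) is therefore expected to stay within the usual scatter, favouring neither direction. Compound 3 is estimated at 7000 nM with an expected range from 2000 nM to 30000 nM across repeat measurements.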

Compound 3, half-maximal inhibitory concentration: 20000 nM
Estimate against measurement, compound 3: 2.9-fold (0.46 log units) below, within the range that was stated.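

In this assay, putting 2,3-difluoro-4-nitrophenyl in place of 3,5-difluoro-2-nitrophenyl on the amine nitrogen gives a 2.6-fold higher number from compound 2 to compound 3 (0.41 log units; beyond the scatter). Going by these compounds alone, this is the first readable step, and it shows that the read-out responds to how the same atoms are joined at this position. The one limit shown belongs to compound 1 and gives no cause for the step: the limit of > 100000 nM in this assay, at which 1 of the 3 values shown sits.

Still open, from the compounds shown here alone, is whether a ring carrying an amine in place of the nitro group would follow the same trend. Also open, going by these compounds, is whether the step holds with free carboxylic acids in place of the esters.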